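Amide aryl variation in a dodecyltetrazole amide series

The source may hold more compounds than are shown below. What is called first, only, known or untested is meant among the compounds shown, and "the series" means these compounds.

Measured compounds in an assay on microsomes from liver for inhibition of sterol O-acyltransferase 1 (Rattus norvegicus); on this read-out lower numbers stand for stronger inhibition and higher numbers for weaker inhibition:
compound 1, `CCCCCCCCCCCCn1nnc(C(NC(=O)c2c(C)cccc2C)c2ccccc2)n1`: compound 1 gives 310 nM
compound 2, `CCCCCCCCCCCCn1nnc(C(NC(=O)c2ccccc2[N+](=O)[O-])c2ccccc2)n1`: compound 2 gives 240 nM
compound 3, `CCCCCCCCCCCCn1nnc(C(NC(=O)c2ccccc2C(F)(F)F)c2ccccc2)n1`: compound 3 gives 120 nM

Compound 3 has the lowest of the three numbers. Its distance from compound 2 is a 2.0-fold lower number from compound 2 to compound 3 (0.30 log units; within the scatter), and from compound 1 it is a 2.6-fold lower number from compound 1 to compound 3 (0.41 log units; beyond the scatter), so only the latter separation stands clear of the scatter; the step of a 1.3-fold lower number from compound 1 to compound 2 (0.11 log units; within the scatter) between the other two does not.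

Compound 4, `CCCCCCCCCCCCn1nnc(C(NC(=O)c2ccnc(SC)c2)c2ccccc2)n1`, is the next point. Relative to compound 3 the change is a group of 8 heavy atoms (6 carbon, 1 nitrogen, 1 sulfur; one six-membered aromatic ring with 1 hetero atom) in place of a group of 10 heavy atoms (7 carbon, 3 fluorine; one six-membered aromatic ring of carbon only), on a carbonyl carbon. None of the three measured steps bears on this change directly: each of them swaps one substituted six-membered carbon-only ring for another on the carbonyl carbon, whereas here a ring with one hetero atom and a methylthio group enters and the trifluoromethyl leaves. The measured aryl variants all fall inside the span given by a 2.6-fold lower number from compound 1 to compound 3 (0.41 log units; beyond the scatter). Going by the values given here, with no step to anchor the heteroaryl, the number for compound 4 is expected to sit above that of compound 3 and the step of a 3.3-fold higher number from compound 3 to compound 4 (0.52 log units; beyond the scatter) is the estimated movement. Compound 4 is therefore estimated at 400 nM, with a range from 120 nM to 1500 nM.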

Compound 4, half-maximal inhibitory concentration: 80 nM
Estimate against measurement, compound 4: 5.0-fold (0.70 log units) above; the whole stated range lies above it.
By their numbers in this assay, from the lowest: compounds 4, 3, 2 and 1 (each within the scatter of the next, the first and the last beyond it).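

In this assay the step of a 1.5-fold lower number from compound 3 to compound 4 (0.18 log units; within the scatter) stays within the scatter, so at this carbonyl carbon a six-membered aromatic ring with 1 hetero atom and a methylthio group matches 2-(trifluoromethyl)phenyl and a carbon-only ring is not needed to hold the number at this level. The steps of a 3.0-fold lower number from compound 2 to compound 4 (0.48 log units; beyond the scatter) and a 3.9-fold lower number from compound 1 to compound 4 (0.59 log units; beyond the scatter) both lie beyond the scatter, and the first is new in kind: the earlier step from the nitro compound to the trifluoromethyl compound stayed within the scatter, so this is the first aryl change shown that stands clear of 2-nitrophenyl. The entering group counts 2 hydrogen-bond acceptors against 0 for the group it replaces, and that swap comes with no rise in the number.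

From the compounds shown here alone, the ring nitrogen and the methylthio group enter together, so their separate shares remain open, as does what a methoxy group or an amine in place of methylthio, or a shorter chain in place of dodecyl, would do to the number. No measurement among those shown accounts for any of these steps.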